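Halogen Variation on the Amide Aryl Ring

The compounds below may be only part of what the source reports. "The series", "measured", "known", "first", "only" and "open" are said of these compounds alone.

Measured compounds in a functional assay on NCI-H1975 cells (Homo sapiens) for inhibition, read by MTT assay, with a stated time of 72 h; a lower number here means a stronger inhibitor, a higher number a weaker inhibitor:
compound 1, `O=C(CSc1nc(Nc2ccccc2)c2ccccc2n1)Nc1ccccc1F`, gives 9350 nM
compound 2, `O=C(CSc1nc(Nc2ccccc2)c2ccccc2n1)Nc1ccccc1Cl`, gives 9610 nM
compound 3, `O=C(CSc1nc(Nc2ccccc2)c2ccccc2n1)Nc1ccc(F)cc1`, gives 16500 nM

All three share one core and differ only in the aryl group on the amide-type nitrogen. Compound 3 has the highest number of the three, yet its distance to either neighbour is small: a 1.8-fold higher number from compound 1 to compound 3 (0.25 log units; within the scatter) and a 1.7-fold higher number from compound 2 to compound 3 (0.23 log units; within the scatter) both stay within the scatter. The halogen swap between compound 1 and compound 2 is likewise flat, a 1.0-fold higher number from compound 1 to compound 2 (0.01 log units; within the scatter).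

Compound 4, `O=C(CSc1nc(Nc2ccccc2)c2ccccc2n1)Nc1ccc(Cl)c(Cl)c1`, is the next step from compound 3: 3,4-dichlorophenyl in place of 4-fluorophenyl on an amide-type nitrogen. Two earlier steps bear on it. Exchanging chloro for fluoro on the aromatic carbon did nothing beyond the scatter, and moving a single halogen to another position on this ring did nothing beyond the scatter either. Compound 4 combines both kinds of change, but with no evidence that either moves this assay, no shift beyond the scatter is expected, a 1.2-fold lower number from compound 3 to compound 4 (0.07 log units; within the scatter).

Compound 4 is therefore estimated at 14000 nM, with a range from 6000 nM to 35000 nM.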

Compound 4, half-maximal inhibitory concentration: 10400 nM
Compound 4: middle estimate off by 1.3-fold (0.13 log units), on the high side; the measured number falls inside the stated range.
By their numbers in this assay, from the lowest: compounds 1, 2, 4 and 3 (each within the scatter of the next).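

In this assay, the step to the 3,4-dichlorophenyl group on the amide-type nitrogen, with two chlorine atoms in place of the single fluorine of the 4-fluorophenyl group, gives a 1.6-fold lower number from compound 3 to compound 4 (0.20 log units; within the scatter) and so adds a second halogen to this ring without a shift beyond the scatter. The comparisons with the two singly substituted rings agree, with a 1.1-fold higher number from compound 2 to compound 4 (0.03 log units; within the scatter) from the 2-chlorophenyl group and a 1.1-fold higher number from compound 1 to compound 4 (0.05 log units; within the scatter) from the 2-fluorophenyl group, which means that all four halogenated aryl groups shown at this position now lie within the scatter of one another. No outside evidence bears on this flat result.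

The compounds shown carry only fluoro and chloro groups on this aryl ring, so it remains open whether the unsubstituted phenyl group, a methoxy group, an amine or a carboxylic acid on that ring, or a longer chain in place of the ring, would move the number beyond the scatter. Also open, from the compounds shown here alone, is whether changes elsewhere on the shared core, such as at its phenylamino group, would do so.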